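The source may report more compounds than this note shows. Statements on the series, on what has been measured and on what is new or still open speak of the compounds shown alone.

In a functional assay on MIA PaCa-2 cells (Homo sapiens) for inhibition, read by MTT assay (a lower number here means a stronger inhibitor, a higher number a weaker inhibitor), three compounds have been measured:

Compound 1 `CN(C)C(=O)c1cc2cnc(NC3CCCCC3)nc2n1C1CCCC1`: 25000 nM
Compound 2 `CN(C)C(=O)c1cc2cnc(Nc3ccccc3)nc2n1C1CCCC1`: 54900 nM
Compound 3 `O=C(Nc1ccccc1)c1cc2cnc(Nc3ccccc3)nc2n1C1CCCC1`: 14000 nM

Compound 3 cannot be told apart from compound 1 within the usual scatter, and both stand clear of compound 2, which has the highest number. Compound 4 `O=C(Nc1ccccc1)c1cc2cnc(Nc3ccc(N4CCNCC4)cn3)nc2n1C1CCCC1` has 5-(piperazin-1-yl)pyridin-2-yl in place of phenyl on a nitrogen on an aromatic ring.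

For the measured compounds named here, the closest precedent is a change on that same nitrogen, a 2.2-fold higher number from compound 1 to compound 2 (0.34 log units; beyond the scatter), where phenyl replaced cyclohexyl. The other measured change, a 3.9-fold lower number from compound 2 to compound 3 (0.59 log units; beyond the scatter), lies on a carbonyl carbon and bears on this one only loosely. Both were modest, and neither tested a group like the one entering here, so the direction is expected with little certainty. Compound 2, with phenyl on this nitrogen, gave the higher number in a 2.2-fold higher number from compound 1 to compound 2 (0.34 log units; beyond the scatter), so a lower number is expected in this assay when phenyl leaves. The estimated change is a 3.5-fold lower number from compound 3 to compound 4 (0.54 log units; beyond the scatter). For compound 4 the expected value is 4000 nM, within an estimated range of 700 nM to 16000 nM.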

Compound 4, half-maximal inhibitory concentration: 2800 nM
For compound 4 the middle estimate is 1.4-fold (0.15 log units) above the measured one; low and high end bracket the measured number.
By their numbers in this assay, from the lowest: compound 4; then compounds 3 and 1 (each within the scatter of the next); then compound 2.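

In this assay, the step of a 5.0-fold lower number from compound 3 to compound 4 (0.70 log units; beyond the scatter) shows that this nitrogen on an aromatic ring tolerates more than the single rings seen there earlier, cyclohexyl and phenyl. A pyridine ring carrying a piperazine takes the place of phenyl here, and the number falls rather than rises, with the anilino group on the carbonyl carbon unchanged. Nothing available gives a reason for this step.

The compounds shown leave open which part of 5-(piperazin-1-yl)pyridin-2-yl carries the step, since the pyridine and the piperazine enter together, and whether morpholine or methylpiperazine in place of the piperazine would give a similar number. They also leave open whether the same group gives a comparable step with dimethylamino on the carbonyl carbon.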